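Cytotoxicity of Three Ureas and One Still Unmeasured

The source may hold more compounds than are shown below. What is called first, only, known or untested is meant among the compounds shown, and "the series" means these compounds.

Measured in an ADME assay on HEK293 cells (Homo sapiens) for cytotoxicity, with a stated time of 72 h; a lower number here means that less compound is needed, a higher number that more compound is needed for the effect:
Compound 1 `Cc1cc(NC(=O)Nc2ccccc2F)c2ccccc2n1` gives > 25000 nM, which is a limit of the assay rather than a number.
Compound 2 `Cc1cc(NC(=O)Nc2cccc(Cl)c2)c2ccccc2n1` gives 21000 nM.
Compound 3 `Cc1cc(NC(=O)Nc2ccc(O)cc2)c2ccccc2n1` gives > 25000 nM, again only a limit of the assay.

Compound 3 thus sits at the ceiling of this assay, where (the limit of > 25000 nM in this assay, at which 2 of the 3 values shown sit). Compound 4 `Cc1cc(NC(=O)Nc2ccc(C(F)(F)F)cc2)c2ccccc2n1` differs from compound 3 by trifluoromethyl in place of hydroxy on an aromatic carbon. Among the compounds with values here, no measured step exchanges these two groups; the closest are an at least 1.1-fold higher number from compound 2 to compound 3 (0.07 log units; that floor lies within the scatter) and a step that the two limits leave unreadable from compound 1 to compound 3, while an at least 1.1-fold lower number from compound 1 to compound 2 (0.07 log units; that floor lies within the scatter) shows that all three values cluster near the limit. A step beyond the scatter is therefore not expected for compound 4, and a number no higher from compound 3 to compound 4 (the limit leaves the size open) is the estimated step. Compound 4 is expected to give about 25000 nM, between 12000 nM and 60000 nM, quite possibly reported only as a limit.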

Compound 4, half-maximal effective concentration: 25000 nM
Compound 4: the middle estimate sits on the measured number at the digits printed; measured number inside the range.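

In this assay compound 4 gives 25000 nM, and on this aromatic carbon, para to a large group, trifluoromethyl with its 0 hydrogen-bond donors in place of hydroxy gives a number no higher from compound 3 to compound 4 (the limit leaves the size open). Compound 3 gives > 25000 nM, which is a limit of the assay. The size of the change from hydroxy to trifluoromethyl therefore cannot be read: the limit of > 25000 nM in this assay, at which 2 of the 4 values shown sit.

Going by these compounds, what an amine or a carboxylic acid at this place would give stays open. So does whether any group here could bring the number clearly lower.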